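The source may report more compounds than this note shows. Statements on the series, on what has been measured and on what is new or still open speak of the compounds shown alone.

Two compounds with a shared core differ in one group. In an ADME assay on the whole organism for pharmacokinetics, with Rattus norvegicus as the target, read by LC-MS (a lower number here means that a smaller share of the oral dose reaches the circulation, a higher number that a larger share of the oral dose reaches the circulation), compound 1 (`Cc1cc(C(=O)N[C@H]2CCCCC/C=C\[C@@H]3C[C@@]3(C(=O)NS(=O)(=O)C3CC3)NC(=O)[C@@H]3C[C@@H](Oc4nc5ccccc5nc4C)CN3C2=O)no1`) gives 3.9% and compound 2 (`Cc1cc(C(=O)N[C@H]2CCCCC/C=C\[C@@H]3C[C@@]3(C(=O)NS(=O)(=O)C3CC3)NC(=O)[C@@H]3C[C@@H](Oc4nc5ccccc5nc4C(F)(F)F)CN3C2=O)no1`) gives 99.5% as the higher of the two numbers. For the measured compounds named here, the only measured step is a number 95.6 percentage points higher from compound 1 to compound 2 (beyond the scatter) and it is large and beyond the scatter, with trifluoromethyl in place of methyl on an aromatic carbon.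

Compound 3 (`Cc1cc(C(=O)N[C@H]2CCCCC/C=C\[C@@H]3C[C@@]3(C(=O)NS(=O)(=O)C3CC3)NC(=O)[C@@H]3C[C@@H](Oc4nc5cc(F)ccc5nc4C(F)(F)F)CN3C2=O)no1`) keeps everything in compound 2 except for one change, fluoro in place of hydrogen on an aromatic carbon in which fluoro takes the place of hydrogen on an aromatic carbon. Going by the values given here, the measured step exchanged a different group, so its size does not carry over, and no measured compound shows what fluoro does on this core. A share of the dose cannot exceed the whole dose, and compound 2 at 99.5% leaves almost no room upward. Any real step is therefore more likely down than up, and moderate rather than large. The expected step is a number 24.5 percentage points lower from compound 2 to compound 3 (beyond the scatter) in this assay as a rough estimate. The estimate for compound 3 is 75% and the expected range runs from 40% to 100% on this thin evidence.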

Compound 3, oral bioavailability: 28%
Estimate against measurement, compound 3: 47 percentage points above, outside the stated range (below it).
By their numbers in this assay, from the lowest: compound 1; then compound 3; then compound 2.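

Placing one fluoro on an aromatic carbon of the six-membered aromatic ring of carbon only, part of a fused system of two rings, gives in this assay a large change: a number 71.5 percentage points lower from compound 2 to compound 3 (beyond the scatter). The earlier pair showed a change only at the trifluoromethyl position, whereas this result shows that the carbon-only ring also matters, and that even one fluorine atom in place of a hydrogen atom can shift the share of the oral dose reaching the circulation well beyond the usual scatter. Nothing measured on these compounds bears on why the number falls.

The compounds shown leave open whether the fall belongs to fluoro itself or to any group placed on this carbon, and whether it would also appear without the trifluoromethyl group on the core. A chloro or methoxy group on the same carbon, or a fluoro on another carbon of the same ring, would help separate the effect of the group from the effect of its place.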